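The compounds below may be only part of what the source reports. "The series", "measured", "known", "first", "only" and "open" are said of these compounds alone.

Compound 1 `CCCCNc1nc(N)nc2c1CNCC2`: 7.2 uM
Compound 2 `CCCCNc1nc(N)nc2c1CN(C)CC2`: 0.03 uM
Compound 3 `CCCCNc1nc(N)nc2c1CN(Cc1ccccn1)CC2`: 0.07 uM

These three compounds share one core and differ only in what sits on the amine nitrogen in the ring, and all were tested in an assay on HEK293 cells for agonist activity at Toll-like receptor 8 (Homo sapiens), read by a luciferase reporter, with a stated time of 6 h; a higher number here means that more compound is needed for the effect, a lower number that less compound is needed. On the numbers shown compound 3 stands second of three: a 2.3-fold higher number from compound 2 to compound 3 (0.37 log units; beyond the scatter) separates it from the lowest number, and a 100-fold lower number from compound 1 to compound 3 (2.01 log units; beyond the scatter) separates it from the highest. Compound 4 `CCCCNc1nc(N)nc2c1CN(Cc1ccncc1)CC2` has not yet been measured. Its difference from compound 3 is pyridin-4-yl in place of pyridin-2-yl on a saturated chain carbon bound to an amine nitrogen in a ring.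

Within the data shown here, no measured step swaps one pyridinyl for another, so the size of this step has to be judged from what is known. Putting any group in place of hydrogen on the amine nitrogen in the ring brings a large change, seen twice: a 240-fold lower number from compound 1 to compound 2 (2.38 log units; beyond the scatter) and a 100-fold lower number from compound 1 to compound 3 (2.01 log units; beyond the scatter). Adding pyridin-2-yl to the saturated chain carbon bound to that nitrogen brings only a modest change: a 2.3-fold higher number from compound 2 to compound 3 (0.37 log units; beyond the scatter). Rearranging the atoms of a group that is already present looks like a smaller matter than either kind of addition, so the step expected in this assay is no change at the digits printed from compound 3 to compound 4 (within the scatter), with no clear direction. Compound 4 is accordingly estimated at 0.07 uM, between 0.02 uM and 0.3 uM.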

Compound 4, minimum effective concentration: 0.29 uM
The estimate for compound 4 lay 4.1-fold (0.62 log units) below the measured number; measured number inside the range.
By their numbers in this assay, from the lowest: compound 2; then compound 3; then compound 4; then compound 1.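

In this assay, pyridin-4-yl in place of pyridin-2-yl leaves the atoms and the counted donors and acceptors the same, yet the step is beyond the scatter (a 4.1-fold higher number from compound 3 to compound 4 (0.62 log units; beyond the scatter)). So at this position, the way the same atoms are joined within the group matters, and not only which atoms are present. The pyridin-4-yl group also stands further from the small methyl group on the ring nitrogen (a 9.7-fold higher number from compound 2 to compound 4 (0.99 log units; beyond the scatter)) than pyridin-2-yl does (a 2.3-fold higher number from compound 2 to compound 3 (0.37 log units; beyond the scatter)), while a large part of the gain over hydrogen on that nitrogen remains (a 25-fold lower number from compound 1 to compound 4 (1.39 log units; beyond the scatter)), though less than with pyridin-2-yl (a 100-fold lower number from compound 1 to compound 3 (2.01 log units; beyond the scatter)).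

The compounds shown leave open where pyridin-3-yl would fall, and whether phenyl, which has no nitrogen in its ring, or a longer chain such as ethyl or propyl on the ring nitrogen would follow the same trend. Nothing given here explains why the two pyridinyl groups differ.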